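This account rests on a few compounds, and the source may have more. Where it says the series, first, only, none or still open, it means among the compounds named here.

- Compound 1 `CCOC(=O)c1nn(-c2ccccc2)c(-c2ccc(C)cc2)c1CNC(C)(C)C`: 78200 nM; > 585000 nM (2 entries)
- Compound 2 `CC(C)(C)NCc1c(C(=O)O)nn(-c2ccccc2)c1-c1ccccc1`: > 716000 nM

Both compounds were tested in a functional assay on MCF7 cells (Homo sapiens) for inhibition, read by sulforhodamine B assay, with a stated time of 48 h; a lower number here means a stronger inhibitor of growth, a higher number a weaker inhibitor of growth. Compound 1 gives 78200 nM; > 585000 nM (2 entries), so its entries do not come down to one number. Compound 2 has only a limit, > 716000 nM, and a further entry for it also gives no single number. Compound 3 `Cc1ccc(-c2c(CNC(C)(C)C)c(C(=O)O)nn2-c2ccccc2)cc1` differs from compound 2 in one place, with methyl in place of hydrogen on an aromatic carbon, para to a large group: methyl in place of hydrogen on an aromatic carbon. The same difference reads as phenyl to 4-methylphenyl. For the measured compounds named here, no measured step shows what such a change does here, so no change beyond the scatter is expected in this assay. The expected step, an at least 1.4-fold lower number from compound 2 to compound 3 (0.15 log units; that floor lies within the scatter), is that small. For compound 3 the estimated value is 500000 nM, with an expected range from 150000 nM to 900000 nM.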

Compound 3, concentration for 50% growth inhibition: > 688000 nM
Compound 3 was reported as a limit (the forecaster's own chance of this, stated with the estimate: 60%); middle value at least 1.3-fold (0.13 log units) from the limit.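

For the compounds shown here, compound 2 and compound 3 are each known only as a limit, not as a single number, so no step between them can be read. The compounds shown leave open whether methyl in place of hydrogen on an aromatic carbon changes growth inhibition at all.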